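The source may hold more compounds than are shown below. What is called first, only, known or untested is meant among the compounds shown, and "the series" means these compounds.

Of the compounds shown here, three built on one shared core have been measured so far. In a functional assay on cells (Platelet) for inhibition (on this read-out lower numbers stand for stronger inhibition and higher numbers for weaker inhibition), compound 1 `O=c1cc(N2CCNCC2)nc2sc(-c3ccccc3)nn12` gives 3000 nM, compound 2 `C[C@H](N)C(=O)Nc1cccc(-c2nn3c(=O)cc(N4CCNCC4)nc3s2)c1` gives 5870 nM, and compound 3 `NCC(=O)Nc1cc(CO)cc(-c2nn3c(=O)cc(N4CCNCC4)nc3s2)c1` gives 75 nM. Compound 2 therefore sits with compound 1 at the weak end of these numbers, and compound 3 stands well apart from both, at a far lower number.

The next compound, compound 4 `O=C(O)CNc1cccc(-c2nn3c(=O)cc(N4CCNCC4)nc3s2)c1`, differs from compound 2 in one place: carboxymethyl in place of (1-aminoethyl)carbonyl on a nitrogen on an aromatic ring.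

Among the measured compounds shown here, only one measured step bears directly on this change. It is a 2.0-fold higher number from compound 1 to compound 2 (0.29 log units; within the scatter), the step that put ((1-aminoethyl)carbonyl)amino in place of hydrogen on an aromatic carbon, and it stays within the scatter. Compound 3 shows that a much lower number is possible on this core, but it differs from compound 2 in more than one place, and no measured step isolates the reason. For the measured compounds named here, no measured compound carries carboxymethyl, so the direction of any change remains open.

In this assay, no step beyond the scatter is therefore expected, and the range must stay wide. The expected change is small, an estimated 1.3-fold lower number from compound 2 to compound 4 (0.12 log units; within the scatter). The estimate for compound 4 is 4500 nM, with an expected range of 900 nM to 20000 nM.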

Compound 4, half-maximal inhibitory concentration: 2000 nM
Compound 4: the middle estimate sits 2.3-fold (0.35 log units) above what was measured; measured number inside the range.
By their numbers in this assay, from the lowest: compound 3; then compounds 4, 1 and 2 (each within the scatter of the next, the first and the last beyond it).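

In this assay, what sits on this nitrogen on an aromatic ring does matter: carboxymethyl in place of (1-aminoethyl)carbonyl gives a 2.9-fold lower number from compound 2 to compound 4 (0.47 log units; beyond the scatter) and so takes a step beyond the scatter, though only a modest one. Placed against hydrogen, however, (carboxymethyl)amino gives a 1.5-fold lower number from compound 1 to compound 4 (0.18 log units; within the scatter) and stays within the scatter, as ((1-aminoethyl)carbonyl)amino also did, so the two groups can be told apart from each other while neither can be told apart from plain hydrogen on the aromatic carbon. No evidence is available on why the two groups differ.

The compounds shown leave open whether the carboxylic acid of carboxymethyl is what counts, which a methyl ester or a primary amide on the same chain would test, and whether a longer chain such as carboxyethyl would read the same. They also leave open whether a simple acetyl on this nitrogen, with no amine and no acid, would stay within the scatter of hydrogen as well.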